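A few compounds are considered here, and "the series" means these few. Any claim that something is new, unique, unknown or untested is made for them only; others in the source may bear on it.

Measured compounds in an assay on cell membranes for binding affinity to adenosine receptor A1 (Bos taurus), read by radioligand binding; a lower number here means a stronger inhibitor, a higher number a weaker inhibitor:
compound 1 `c1ccc(Cn2nnc3c(NC4CCCC4)ncnc32)cc1` gives 127 nM
compound 2 `CC1CCCC(Nc2ncnc3c2nnn3Cc2ccccc2)C1` gives 770 nM
compound 3 `CC1CCCC(Nc2ncnc3c2nnn3Cc2ccccc2Cl)C1` gives 102 nM

Compound 3 has the lowest number of the three. Its gap to compound 1 lies within the scatter, so the two cannot be ordered; only compound 2 stands clearly apart, the step of a 7.5-fold lower number from compound 2 to compound 3 (0.88 log units; beyond the scatter) being beyond the scatter.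

Compound 4 `Clc1ccccc1Cn1nnc2c(NCC3CCCCC3)ncnc21` differs from compound 3 by cyclohexylmethyl in place of 3-methylcyclohexyl on a nitrogen on an aromatic ring. Within the data shown here, no measured step makes this particular exchange. Among the measured compounds shown here, the one step that touches the group on this nitrogen, a 6.1-fold higher number from compound 1 to compound 2 (0.78 log units; beyond the scatter), shows that a change there moves the number by a modest amount. The other step, a 7.5-fold lower number from compound 2 to compound 3 (0.88 log units; beyond the scatter), concerns the chloro group, which compound 4 keeps, and so says nothing about the new substituent. For the measured compounds named here, with the only precedent at this position pointing to a modest shift and no direct guide, the step to compound 4 is expected to be a 2.9-fold higher number from compound 3 to compound 4 (0.47 log units; beyond the scatter), a modest rise. The estimate for compound 4 in this assay is 300 nM, with a range from 100 nM to 900 nM.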

Compound 4, inhibition constant: 4260 nM
Compound 4: middle estimate off by 14-fold (1.15 log units), on the low side; the measured number lies above the stated range.
By their numbers in this assay, from the lowest: compounds 3 and 1 (each within the scatter of the next); then compound 2; then compound 4.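

In this assay the exchange of 3-methylcyclohexyl for cyclohexylmethyl gives a 42-fold higher number from compound 3 to compound 4 (1.62 log units; beyond the scatter) and is a large step, although the two groups have the same atoms joined differently. This position on the nitrogen therefore responds to the arrangement of the carbons and not merely to their number, and the earlier step at this nitrogen, a 6.1-fold higher number from compound 1 to compound 2 (0.78 log units; beyond the scatter) and modest in size, did not reveal a change of this scale. Compound 4 also keeps the chloro group, so retaining it does not prevent this rise, and no measurement bears on the reason for it.

Still open, on these data alone, is how a plain cyclohexyl or a cyclopentylmethyl on this nitrogen would read, which would help separate ring size from the methylene link. Also open, as far as these compounds go, is whether the chloro group gives a similar step alongside cyclopentyl.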